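Shortening the acid chain of compound 2: an expected outcome

The compounds below may be only part of what the source reports. "The series", "measured", "known", "first", "only" and "open" are said of these compounds alone.

Measured so far:
- compound 1, `O=C(O)/C=C/c1ccccc1-c1ccc(Cl)c(Cl)c1`: 1600 nM
- compound 2, `O=C(O)CCCc1ccccc1-c1cccc(-c2ccccc2OCc2ccccc2)c1`: 590 nM
- compound 3, `O=C(O)CCc1ccccc1-c1ccc(-c2ccccc2OCc2ccccc2)s1`: 520 nM

Of the compounds shown here, three have been tested in an assay on HEK293 cells for binding affinity to prostaglandin E2 receptor EP3 subtype (Homo sapiens); on this read-out higher numbers stand for weaker inhibition and lower numbers for stronger inhibition. Compound 1 gives 1600 nM in this assay, compound 2 gives 590 nM and compound 3 gives 520 nM. Compound 2 stands second highest of the three numbers; its nearest neighbour is compound 3, whose number lies within the scatter of that of compound 2, so the two cannot be told apart on these data, while compound 1 gives a number beyond the scatter above that of compound 2.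

The step followed here leads from compound 2 to compound 4, `O=C(O)CCc1ccccc1-c1cccc(-c2ccccc2OCc2ccccc2)c1`, which has not yet been tested. The change is carboxy in place of carboxymethyl on a saturated chain carbon, two bonds along the chain from an aromatic carbon. Within the data shown here, no other pair among the measured compounds differs in one place only, so no step of this kind has been measured. Compound 3 carries the shorter chain on a related scaffold and gives 520 nM, close to compound 2, which suggests the chain length matters little here. Compound 4 is therefore expected to give about 500 nM in this assay, between 200 nM and 1500 nM. The expected step of a 1.2-fold lower number from compound 2 to compound 4 (0.07 log units; within the scatter) is thus estimated to lie within the scatter, with no clear direction.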

Compound 4, inhibition constant: 55 nM
Estimate against measurement, compound 4: 9.1-fold (0.96 log units) above; the measured number lies below the stated range.
By their numbers in this assay, from the lowest: compound 4; then compounds 3 and 2 (each within the scatter of the next); then compound 1.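

In this assay, the change from 3-carboxypropyl to 2-carboxyethyl on the shared core gives an 11-fold lower number from compound 2 to compound 4 (1.03 log units; beyond the scatter), a large step well beyond the usual scatter. Among these compounds, this is the first pair in the set that differs in one place only, and it shows that the length of the acid chain at this position, on a saturated chain carbon two bonds along the chain from an aromatic carbon, has a strong bearing on the read-out on this core. It rests on this single pair, however, and the data shown offer nothing that explains why the shorter chain gives the lower number.

The compounds shown leave open whether shortening further to carboxymethyl would continue the step or reverse it, and whether a tetrazole or an amide could stand in place of the carboxylic acid at the end of the 2-carboxyethyl chain. They also leave open whether the same change from a 3-carboxypropyl chain to a 2-carboxyethyl chain would give a step of similar size on the core of compound 3.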